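Replacing the methylsulfamoyl group of compound 3 with methyl

The compounds below may be only part of what the source reports. "The series", "measured", "known", "first", "only" and "open" are said of these compounds alone.

In an assay on COS-7 cells for inhibition of patatin-like phospholipase domain-containing protein 2 (Mus musculus) (on this read-out lower numbers stand for stronger inhibition and higher numbers for weaker inhibition), compound 3 `CCOc1ccc(-c2cccc(S(=O)(=O)NC)c2)cc1` gives 200000 nM, the same number at the digits shown as compound 1 `CCNS(=O)(=O)c1cccc(-c2ccc(OCC)cc2)c1` with 200000 nM, and within the scatter of compound 2 `CCOc1ccc(-c2cccc(S(=O)(=O)N(C)C)c2)cc1` with 110000 nM. Compound 4 `CCOc1ccc(-c2cccc(C)c2)cc1` differs from compound 3 by methyl in place of methylsulfamoyl on an aromatic carbon. For the measured compounds named here, none of the measured steps touches this change directly: a 1.8-fold lower number from compound 1 to compound 2 (0.26 log units; within the scatter), no change at the digits printed from compound 1 to compound 3 (within the scatter) and a 1.8-fold higher number from compound 2 to compound 3 (0.26 log units; within the scatter) all alter only the substituents on the sulfonamide nitrogen, and each stays within the scatter. Going by the values given here, no step therefore shows what removing the whole group does, so the expected step of no change at the digits printed from compound 3 to compound 4 (within the scatter) is taken as none beyond the scatter. Compound 4 is expected to give about 200000 nM, between 50000 nM and 1000000 nM in this assay.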

Compound 4, half-maximal inhibitory concentration: 70000 nM
Compound 4: the middle estimate sits 2.9-fold (0.46 log units) above what was measured; the measured number falls inside the stated range.
By their numbers in this assay, from the lowest: compounds 4, 2, 1 and 3 (each within the scatter of the next, the first and the last beyond it).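

In this assay replacing the whole sulfamoyl group with methyl on this aromatic carbon gives steps beyond the scatter, namely a 2.9-fold lower number from compound 3 to compound 4 (0.46 log units; beyond the scatter) and a 2.9-fold lower number from compound 1 to compound 4 (0.46 log units; beyond the scatter), whereas changes on the sulfonamide nitrogen alone stayed within it. The third step, a 1.6-fold lower number from compound 2 to compound 4 (0.20 log units; within the scatter), stays within the scatter, so among these compounds the sulfonamide is not required for the inhibition seen. Nothing available here explains these differences.

From the compounds shown here alone, whether a carboxylic acid, an amine or a longer chain at this place would give a lower number remains open. So does the effect of plain hydrogen there.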